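Aryl replacements for the methoxypropynyl group: microsomal clearance notes

The source may hold more compounds than are shown below. What is called first, only, known or untested is meant among the compounds shown, and "the series" means these compounds.

Measured compounds:
compound 1 `COCC#Cc1cc(C(O)(C(F)(F)F)C(F)(F)F)cnc1N1CCN(S(=O)(=O)c2ccc(N)nc2)CC1` — 15 mL.min-1.g-1
compound 2 `Nc1ccc(S(=O)(=O)N2CCN(c3ncc(C(O)(C(F)(F)F)C(F)(F)F)cc3-c3ccccc3O)CC2)cn1` — 22 mL.min-1.g-1
compound 3 `CS(=O)(=O)Nc1cccc(-c2cc(C(O)(C(F)(F)F)C(F)(F)F)cnc2N2CCN(S(=O)(=O)c3ccc(N)nc3)CC2)c1` — 40 mL.min-1.g-1

In an ADME assay (liver) for metabolic stability, with Liver microsome (Homo sapiens) as the target, using microsomes and NADPH, with a stated time of 30 min, tested at 1 uM (on this read-out higher numbers stand for fast clearance and lower numbers for slow clearance), compound 1 gives 15 mL.min-1.g-1, the lowest of the three numbers recorded; compound 2 sits nearest, compound 3 furthest. The measured step of a 1.5-fold higher number from compound 1 to compound 2 (0.17 log units; within the scatter) stays within the scatter, whereas a 2.7-fold higher number from compound 1 to compound 3 (0.43 log units; beyond the scatter) is a modest rise beyond it. Between the two aryl analogues, a 1.8-fold higher number from compound 2 to compound 3 (0.26 log units; within the scatter) is again within the scatter.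

Compound 4 `Cc1nc2cc(-c3cc(C(O)(C(F)(F)F)C(F)(F)F)cnc3N3CCN(S(=O)(=O)c4ccc(N)nc4)CC3)ccc2o1` has not yet been measured in this assay. Relative to compound 1 the change is 2-methyl-1,3-benzoxazol-5-yl in place of 3-methoxyprop-1-yn-1-yl on an aromatic carbon. Both measured steps from compound 1 replace the same 3-methoxyprop-1-yn-1-yl with an aromatic group, one of them within the scatter and one a modest rise, so a small to modest rise is the expectation here, with no basis for a fall. The step from compound 1 to compound 4 is therefore estimated as a 1.9-fold higher number from compound 1 to compound 4 (0.27 log units; within the scatter). Compound 4 is expected to give about 28 mL.min-1.g-1 in this assay, with a likely range of 14 mL.min-1.g-1 to 55 mL.min-1.g-1.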

Compound 4, intrinsic clearance in microsomes: < 14 mL.min-1.g-1
Compound 4 gave a limit, no number (the forecaster's own chance of this, stated with the estimate: 3%); middle value at least 2.0-fold (0.30 log units) from the limit.
By their numbers in this assay, from the lowest: compounds 1, 2 and 3 (each within the scatter of the next, the first and the last beyond it). At a limit, below all of these: compound 4.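

In this assay compound 4 gives a limit and not a number: the limit of < 14 mL.min-1.g-1 in this assay, at which 1 of the 4 values shown sits. The new result shows that a larger aromatic group at this position, ortho to a large group, need not raise the clearance number: 2-methyl-1,3-benzoxazol-5-yl gives an at least 1.0-fold lower number from compound 1 to compound 4 (0.02 log units; that floor lies within the scatter), so it cannot be placed as a true fall from the 3-methoxyprop-1-yn-1-yl group, yet no rise appears. Among the aromatic replacements, the 2-hydroxyphenyl comparison is an at least 1.5-fold lower number from compound 2 to compound 4 (0.19 log units; that floor lies within the scatter), while the 3-(methanesulfonamido)phenyl comparison is an at least 2.8-fold lower number from compound 3 to compound 4 (0.45 log units; beyond the scatter), the first firm separation among these aromatic groups.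

From the compounds shown here alone, how far compound 4 lies under its limit remains open, and with it the true size of each step. Also open, going by these compounds, is whether a carboxylic acid or a morpholine at this position on the shared core would give a similarly low number.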